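Swapping an Aryl Ether for a Benzylamine

The source may report more compounds than this note shows. Statements on the series, on what has been measured and on what is new or still open speak of the compounds shown alone.

Among the compounds with values here, compound 1 `Nc1cc(N)c2nc(-c3ccccc3)c(Oc3ccc(Cl)c(Cl)c3)nc2c1` is the only member of this set with a plain number in a functional assay on HOP-62 cells (Homo sapiens) for inhibition, read by sulforhodamine B assay, with a stated time of 48 h (on this read-out lower numbers stand for higher toxicity in this test and higher numbers for lower toxicity in this test), where compound 1 gives 85100 nM. Compound 2 `CCOC(=O)[C@H](CCC(=O)O)NC(=O)c1ccc(Sc2nc3cc(N)cc(N)c3nc2-c2ccccc2)cc1` reaches only a limit of the test, < 100000 nM. Compound 3 `COc1cc(CNc2nc3cc(N)cc(N)c3nc2-c2ccccc2)cc(OC)c1OC` also sits at a limit, < 50200 nM. Compound 4 `Nc1cc(N)c2nc(-c3ccccc3)c(NCc3ccc(F)cc3)nc2c1` has not been measured yet; it differs from compound 1 by (4-fluorobenzyl)amino in place of 3,4-dichlorophenoxy on an aromatic carbon. Within the data shown here, no pair of measured compounds differs in just one place, so there is no direct precedent for this change. The step is expected to be a 1.4-fold lower number from compound 1 to compound 4 (0.15 log units; within the scatter), a shift toward somewhat higher toxicity that may stay within the scatter. Compound 4 is expected to give 60000 nM, between 20000 nM and 150000 nM.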

Compound 4, concentration lethal to 50% of the cells: < 100000 nM
Compound 4: a limit, no number; the forecaster's own chance of this, stated with the estimate: 30%; the middle value is on the limit's open side.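

Compound 4 gives < 100000 nM, which is a limit of the test and not a number, and the step from compound 1 to compound 4 cannot be read. The compounds shown leave open whether (4-fluorobenzyl)amino in place of 3,4-dichlorophenoxy changes the result in this assay at all, and in which direction.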